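Changing the Amide Aryl Group: Expectation for Compound 3

The source may report more compounds than this note shows. Statements on the series, on what has been measured and on what is new or still open speak of the compounds shown alone.

Measured so far in a functional assay on A549 cells (Homo sapiens) for antiproliferative activity, read by MTT assay, with a stated time of 72 h; a higher number here means a weaker inhibitor, a lower number a stronger inhibitor:
compound 1 `COc1cc(N(C)C)c(NC(=O)c2ccncc2)cc1Nc1nccc(-c2cn(C)c3ccccc23)n1`, 9000 nM
compound 2 `COc1ccc(C(=O)Nc2cc(Nc3nccc(-c4cn(C)c5ccccc45)n3)c(OC)cc2N(C)C)nc1`, 5150 nM

In this assay compound 2 and compound 1 lie within the scatter of each other, so neither can be placed ahead of the other. Compound 3 `COc1cc(N(C)C)c(NC(=O)c2c[nH]cn2)cc1Nc1nccc(-c2cn(C)c3ccccc23)n1` differs from compound 2 in one place: 1H-imidazol-4-yl in place of 5-methoxypyridin-2-yl on a carbonyl carbon. For the measured compounds named here, the only measured step at that same carbonyl carbon, a 1.7-fold lower number from compound 1 to compound 2 (0.24 log units; within the scatter), exchanged one aromatic ring for another and stayed within the scatter. With that single step as guide, no shift beyond the scatter is expected, and a 1.2-fold higher number from compound 2 to compound 3 (0.07 log units; within the scatter) is the estimated step. Compound 3 is therefore expected near 6000 nM, between 2500 nM and 15000 nM.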

Compound 3, half-maximal inhibitory concentration: 3560 nM
The estimate for compound 3 lay 1.7-fold (0.23 log units) above the measured number, within the range that was stated.
By their numbers in this assay, from the lowest: compounds 3, 2 and 1 (each within the scatter of the next, the first and the last beyond it).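

In this assay a five-membered ring, 1H-imidazol-4-yl, can take the place of a six-membered aromatic ring on this carbonyl carbon, and a 1.4-fold lower number from compound 2 to compound 3 (0.16 log units; within the scatter) shows no separation from the methoxypyridine. Against the pyridin-4-yl group, a 2.5-fold lower number from compound 1 to compound 3 (0.40 log units; beyond the scatter) is the first step at this position to clear the scatter, though only modestly. Nothing measured here explains why the numbers differ.

Still open, going by these compounds, is whether an aromatic ring is needed here at all, which a saturated ring such as piperidine or a plain amine could test. A methyl group on the imidazole ring nitrogen would ask whether the hydrogen there matters.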